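Amide variation across two measured pairs

A few compounds are considered here, and "the series" means these few. Any claim that something is new, unique, unknown or untested is made for them only; others in the source may bear on it.

Compound 1, `CCOC(=O)c1csc2nc(-c3cccc(NC(=O)c4ccco4)c3)cn12`, in a functional assay on MV4-11 cells (Homo sapiens) for cytotoxicity, read by MTT assay, with a stated time of 72 h (on this read-out lower numbers stand for stronger inhibition and higher numbers for weaker inhibition), reports only a limit, > 20000 nM.
Compound 2, `CCOC(=O)c1csc2nc(-c3ccc(NC(=O)c4ccco4)cc3)cn12`, in this assay gives 9920 nM.
Compound 3, `CCOC(=O)c1csc2nc(-c3cccc(NC(=O)CCl)c3)cn12`, in this assay gives 17700 nM.

Compound 1 and compound 2 contain the same atoms joined differently; the difference between the two cores is not broken down here. Compound 3 derives from compound 1 by chloromethyl in place of furan-2-yl on a carbonyl carbon. Compound 1 sits at the limit of > 20000 nM in this assay, at which 1 of the 3 values shown sits. The measured step was an at least 1.1-fold lower number from compound 1 to compound 3 (0.05 log units; that floor lies within the scatter). Compound 4, `CCOC(=O)c1csc2nc(-c3ccc(NC(=O)CCl)cc3)cn12`, is the unmeasured partner of compound 2 under (chloromethyl in place of furan-2-yl on a carbonyl carbon). The surroundings of the carbonyl carbon read alike in both pairs, so this is the same change. Because an at least 1.1-fold lower number from compound 1 to compound 3 (0.05 log units; that floor lies within the scatter) lies within the scatter, a step of about the same size is expected a 1.1-fold lower number from compound 2 to compound 4 (0.04 log units; within the scatter). Compound 4 is estimated at 9000 nM, with an expected range from 4000 nM to 20000 nM.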

Compound 4, half-maximal inhibitory concentration: 9070 nM
Estimate against measurement, compound 4: 1.0-fold (0.00 log units) below; low and high end bracket the measured number.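

In this assay, chloromethyl in place of furan-2-yl on the carbonyl carbon gives a 1.1-fold lower number from compound 2 to compound 4 (0.04 log units; within the scatter). Set beside the earlier pair, the change reads alike only as far as it can be read: the same change on two cores in this assay, an at least 1.1-fold lower number (0.05 log units; that floor lies within the scatter) from compound 1 to compound 3 and a 1.1-fold lower number (0.04 log units; within the scatter) from compound 2 to compound 4; the limit leaves it open whether they differ. Compound 1 reports only a limit, > 20000 nM; the step on its core has no measured size, and a matching step on the two cores is not shown.

Open, going by these compounds, is whether an aminomethyl group or a longer chain on the same carbonyl carbon would read like chloromethyl or furan-2-yl. Also open, on these data alone, is whether the change reads the same on a core carrying a carboxylic acid in place of the ethyl ester.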